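The source may report more compounds than this note shows. Statements on the series, on what has been measured and on what is new or still open speak of the compounds shown alone.

Working notes on the series. Of the compounds shown here, two of the shared core have numbers so far. Compound 1 `N#C/N=C1\N(CCCCCCCOc2ccc(Cl)cc2)C(=O)CN1c1ccncc1` gives 926 nM in a functional assay on NUGC cells (stomach, Homo sapiens) for cytotoxicity; a lower number here means a stronger inhibitor, a higher number a weaker inhibitor. Compound 2 `N#C/N=C1\N(CCCCCOc2ccc(Cl)cc2)C(=O)C(c2ccccc2)N1c1ccncc1` differs from it in both a phenyl and the chain length; in this assay compound 2 gives 3450 nM, the higher of the two numbers, and its gap to compound 1 lies beyond the scatter. Since the two measured compounds differ in two places at once, the phenyl and the chain cannot be separated on these data. Compound 3 `N#C/N=C1\N(CCCCCCCOc2ccc(Cl)cc2)C(=O)C(c2ccccc2)N1c1ccncc1` is the next point: 2-(4-chlorophenoxy)ethyl in place of 4-chlorophenoxy on a saturated chain carbon, five bonds along the chain from an amide-type nitrogen in a ring. Compound 3 thus combines the longer chain seen in compound 1 with the phenyl seen in compound 2. A step of about a 2.2-fold lower number from compound 2 to compound 3 (0.33 log units; beyond the scatter) is expected, lowering the number, though a step within the scatter cannot be ruled out. Compound 3 is estimated at 1600 nM, with a range from 500 nM to 5000 nM.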

Compound 3, half-maximal inhibitory concentration: 3350 nM
The estimate for compound 3 lay 2.1-fold (0.32 log units) below the measured number; the range from low to high includes it.
By their numbers in this assay, from the lowest: compound 1; then compounds 3 and 2 (each within the scatter of the next).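

With the phenyl held on the saturated ring carbon, 2-(4-chlorophenoxy)ethyl in place of 4-chlorophenoxy gives a 1.0-fold lower number from compound 2 to compound 3 (0.01 log units; within the scatter) in this assay and so separates compound 2 and compound 3 by nothing beyond the scatter. With the longer chain held, phenyl in place of hydrogen on a saturated ring carbon gives a 3.6-fold higher number from compound 1 to compound 3 (0.56 log units; beyond the scatter) as a modest step, so the phenyl can now be read apart from the chain. No measurement at hand gives a cause for either step.

On these data alone, whether the chain change has the same small size when hydrogen stands on that ring carbon remains open. Also open, as far as these compounds go, is how a methyl or benzyl group on that carbon, or a fluorine in place of the chlorine on the phenoxy ring, would read in this assay on this core.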